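Cyano in place of trifluoromethoxy: working notes on the series

This account rests on a few compounds, and the source may have more. Where it says the series, first, only, none or still open, it means among the compounds named here.

Measured so far in a functional assay on LNCaP cells (Homo sapiens) for antiproliferative activity, read by propidium iodide staining, with a stated time of 96 h; on this read-out lower numbers stand for stronger inhibition and higher numbers for weaker inhibition:
- compound 1 `CC(O)(COc1ccc(C(F)(F)F)cc1)C(=O)Nc1cccc(S(F)(F)(F)(F)F)c1`: 9600 nM
- compound 2 `CC(O)(COc1ccc(OC(F)(F)F)cc1)C(=O)Nc1cccc(S(F)(F)(F)(F)F)c1`: 12700 nM

Going by the values given here, only two numbers are available, and compound 2 at 12700 nM stands level with compound 1 within the scatter. Compound 3 `CC(O)(COc1ccc(C#N)cc1)C(=O)Nc1cccc(S(F)(F)(F)(F)F)c1` has yet to be measured in this assay. It carries cyano in place of trifluoromethoxy on an aromatic carbon, para to a large group: cyano in place of trifluoromethoxy on an aromatic carbon.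

Among the compounds with values here, one measured step bears on this change: a 1.3-fold higher number from compound 1 to compound 2 (0.12 log units; within the scatter), with trifluoromethoxy in place of trifluoromethyl on an aromatic carbon. That step exchanges one fluorine-bearing group for another, whereas cyano carries no fluorine, so the guidance is thin. The data give no direction for the new step. On the evidence of a 1.3-fold higher number from compound 1 to compound 2 (0.12 log units; within the scatter), no change beyond the scatter is expected in this assay, though the range is kept wide. The estimated step is a 1.1-fold lower number from compound 2 to compound 3 (0.02 log units; within the scatter). For compound 3 the expected value is 12000 nM, with an estimated range of 5000 nM to 29000 nM.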

Compound 3, half-maximal inhibitory concentration: 30000 nM
Beside the measured number, compound 3's estimate is 2.5-fold (0.40 log units) below it, outside the stated range (above it).
By their numbers in this assay, from the lowest: compounds 1 and 2 (each within the scatter of the next); then compound 3.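

In this assay, this position, on an aromatic carbon para to a large group, now proves sensitive to the choice of group, which the two fluorine-bearing groups alone did not reveal: cyano in place of trifluoromethoxy gives a clear loss (a 2.4-fold higher number from compound 2 to compound 3 (0.37 log units; beyond the scatter)), and cyano in place of trifluoromethyl gives a loss in the same direction (a 3.1-fold higher number from compound 1 to compound 3 (0.49 log units; beyond the scatter)). Both steps lie beyond the scatter, so compound 3 is the weakest of the three, while compound 1 and compound 2 remain level with each other. Nothing measured here explains this shift.

The compounds leave open whether the shift tracks the loss of fluorine or the drop from five heavy atoms to two in trifluoromethoxy versus cyano, and a chlorine atom, a methyl group or a methoxy group at this place would help separate the two readings. Also open, going by these compounds, is where an amine or a carboxylic acid at this place would fall relative to compound 1 and compound 3, and whether the same order holds with other groups elsewhere on the shared core.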